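A few compounds are considered here, and "the series" means these few. Any claim that something is new, unique, unknown or untested is made for them only; others in the source may bear on it.

In a functional assay on cells (Homo sapiens) for cytotoxicity, read by MTT assay, with a stated time of 24 h (on this read-out higher numbers stand for weaker inhibition and lower numbers for stronger inhibition), compound 1 `CCCCCCCCCCCCCCNC(=O)[C@H](CO)NCc1ccccc1O` gives 75300 nM and compound 2 `CCCCCCCCCCCCCCNC(=O)[C@H](CO)NCc1ccccc1OC` gives 100000 nM while compound 3 `CCCCCCCCCCCCCCNC(=O)[C@H](CO)/N=C/c1ccc(C)cc1` gives 102000 nM on the same scale. These three numbers lie within the scatter of one another, so compound 3 stands level with the other two and none of them can be ranked.

Compound 4 `CCCCCCCCCCCCCCNC(=O)[C@H](CO)/N=C/c1cccc(O)c1` carries 3-hydroxyphenyl in place of the 4-methylphenyl of compound 3 on a carbon with a double bond to nitrogen 3-hydroxyphenyl in place of 4-methylphenyl on a carbon with a double bond to nitrogen and it has not yet been measured. Among the compounds with values here, no measured pair makes exactly this swap, so the guidance is indirect. Putting methyl in place of hydrogen on an oxygen on an aromatic ring gave a 1.3-fold higher number from compound 1 to compound 2 (0.12 log units; within the scatter) and the two broader exchanges of the aromatic group gave a 1.4-fold higher number from compound 1 to compound 3 (0.13 log units; within the scatter) and also a 1.0-fold higher number from compound 2 to compound 3 (0.01 log units; within the scatter) in the same read-out. All three steps stay inside the scatter, so among these compounds nothing yet points to a real shift, and no step beyond the scatter is expected here. The expected step is a 1.1-fold lower number from compound 3 to compound 4 (0.05 log units; within the scatter) as an estimate only. For compound 4 the estimated value is 90000 nM with an expected range from 50000 nM to 160000 nM as the likely span.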

Compound 4, half-maximal inhibitory concentration: 32600 nM
Compound 4: the middle estimate sits 2.8-fold (0.44 log units) above what was measured, outside the stated range (below it).
By their numbers in this assay, from the lowest: compound 4; then compounds 1, 2 and 3 (each within the scatter of the next).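

In this assay, 3-hydroxyphenyl in place of 4-methylphenyl on a carbon with a double bond to nitrogen gives a 3.1-fold lower number from compound 3 to compound 4 (0.50 log units; beyond the scatter), the first step among these compounds to pass the scatter, so a change at this place can move the read-out. Compound 4 also stands apart from the other two compounds, with a 3.1-fold lower number from compound 2 to compound 4 (0.49 log units; beyond the scatter) and a 2.3-fold lower number from compound 1 to compound 4 (0.36 log units; beyond the scatter), which makes it the most potent of the four, though only by modest steps; a hydroxyl on the aromatic ring is not enough on its own, since compound 1 also carries one and goes against that idea. Nothing measured here explains why this change lowers the number.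

The step from compound 3 to compound 4 removes a methyl, adds a hydroxyl and uses a different ring position all at once, so the compounds shown cannot say which of these matters. Going by these compounds, it also remains open whether an amine or a carboxylic acid on the ring in place of the hydroxyl would give a similar number.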